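Chain extension in a triazole aryl ether anticonvulsant series

The compounds below may be only part of what the source reports. "The series", "measured", "known", "first", "only" and "open" are said of these compounds alone.

Measured so far, in a functional assay on the whole organism (strain C57B/6) with Mus musculus as the target, in the maximal electroshock model; a higher number here means that more compound is needed for the effect, a lower number that less compound is needed:
Compound 1 `CCCCOc1ccc(-n2cnnc2CC)cc1` gives only the assay limit > 100 mg/kg.
Compound 2 `CCCCCCCOc1ccc(-n2cnnc2CC)cc1` gives 8.3 mg/kg.
Compound 3 `CCCCCCCCOc1ccc(-n2cnnc2CC)cc1` gives 8.8 mg/kg.

Compound 3 stands at the higher of the two numbers read, with compound 2 at a distance within the scatter, a 1.1-fold higher number from compound 2 to compound 3 (0.03 log units; within the scatter); the remaining value is a limit. Compound 1 is the one that gives only a limit, (the limit of > 100 mg/kg in this assay, at which 1 of the 3 values shown sits).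

Compound 4 `CCCCCCCCCCCCOc1ccc(-n2cnnc2CC)cc1` differs from compound 3 by butyl in place of hydrogen on a saturated chain carbon, eight bonds along the chain from an oxygen on an aromatic ring. Two measured steps lengthen the same chain from compound 1 and are large: an at least 12-fold lower number from compound 1 to compound 2 (1.08 log units; beyond the scatter) and an at least 11-fold lower number from compound 1 to compound 3 (1.05 log units; beyond the scatter). The step that most resembles the present change, growth at the chain end, is a 1.1-fold higher number from compound 2 to compound 3 (0.03 log units; within the scatter), within the scatter. The expectation for this assay is therefore no step beyond the scatter, read as a 1.4-fold higher number from compound 3 to compound 4 (0.13 log units; within the scatter), with some allowance for a rise because the two large steps both start from the limit of > 100 mg/kg in this assay, at which 1 of the 3 values shown sits, and nothing shows the fall continuing. Compound 4 is expected to give 12 mg/kg, estimated between 5 mg/kg and 40 mg/kg.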

Compound 4, dose for half-maximal effect: > 100 mg/kg
Compound 4: only a limit was reported; the forecaster's own chance of this, stated with the estimate: 15%; middle value at least 8.3-fold (0.92 log units) from the limit.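

In this assay, growth at the chain end is no longer neutral at this position: butyl in place of hydrogen, eight bonds along the chain from an oxygen on an aromatic ring, gives an at least 11-fold higher number from compound 3 to compound 4 (1.05 log units; beyond the scatter), and the matching pentyl change gives an at least 12-fold higher number from compound 2 to compound 4 (1.08 log units; beyond the scatter). Chain length therefore does not follow one direction across these four compounds, as compound 2 and compound 3 stand apart from both the shorter chain of compound 1 and the longer chain of compound 4. Compound 1 and compound 4 each give only a limit, the step between them cannot be read, and both sit at the same value: the limit of > 100 mg/kg in this assay, at which 2 of the 4 values shown sit.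

Where along the chain the number rises remains open, and a decyl chain would narrow that range. The compounds shown also do not tell why the longer chain loses the effect, or whether an amine at the chain end would change the outcome.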